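Taking one methyl off the slowest-cleared compound

The source may hold more compounds than are shown below. What is called first, only, known or untested is meant among the compounds shown, and "the series" means these compounds.

Among the compounds with values here, in an ADME assay on the whole organism (blood, strain Han-Wistar) for pharmacokinetics, with Rattus norvegicus as the target, read by LC-MS, at a dose of 1 mg/kg by the intravenous route (on this read-out lower numbers stand for slow clearance and higher numbers for fast clearance), compound 1 `Cc1ccc([C@@H](C)Oc2cc3onc(CCC(=O)O)c3cc2Cl)nc1` gives 1.1 mL/min/kg, the lowest of the three numbers so far. Compound 2 `O=C(O)CCn1c(=O)oc2cc(OCC3CC3)c(Cl)cc21` gives 4.1 mL/min/kg and compound 3 `CCOc1cc2oc(=O)n(CCC(=O)O)c2cc1Cl` gives 16 mL/min/kg, and both lie beyond the usual scatter from compound 1.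

Compound 4 `C[C@@H](Oc1cc2onc(CCC(=O)O)c2cc1Cl)c1ccccn1` differs from compound 1 in one place: hydrogen in place of methyl on an aromatic carbon. Hydrogen stands in place of methyl on an aromatic carbon, turning 5-methylpyridin-2-yl into pyridin-2-yl.

Within the data shown here, no measured step makes this exact change. The closest guide is a 3.9-fold higher number from compound 2 to compound 3 (0.59 log units; beyond the scatter), where methyl replaces cyclopropyl on a saturated chain carbon bound to an oxygen on an aromatic ring. That step also swaps a group for a smaller one, but it sits at a different place on a different core, so it is weak evidence.

A smaller rise in the same direction is therefore expected, and it may stay within the scatter: the estimated change is a 1.5-fold higher number from compound 1 to compound 4 (0.16 log units; within the scatter). Compound 4 is expected near 1.6 mL/min/kg, with an estimated range of 0.7 mL/min/kg to 4 mL/min/kg.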

Compound 4, clearance: 0.8 mL/min/kg
Compound 4: the middle estimate sits 2.0-fold (0.30 log units) above what was measured, within the range that was stated.
By their numbers in this assay, from the lowest: compounds 4 and 1 (each within the scatter of the next); then compound 2; then compound 3.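

In this assay, replacing the methyl of the 5-methylpyridin-2-yl group with hydrogen gives a 1.4-fold lower number from compound 1 to compound 4 (0.14 log units; within the scatter), so the two compounds cannot be told apart on this read-out. Within the data shown here, this is the first direct look at this aromatic carbon, two atoms from the ring nitrogen and para to a large group, and it shows that a low clearance number does not depend on having the methyl there. No measurement shown here bears on the reason for this result.

A single swap from methyl to hydrogen cannot show how a fluorine, a methoxy group or a nitrile on this same carbon would read. It also leaves open whether an ethyl group or a longer chain there would give a similar number.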